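The source may hold more compounds than are shown below. What is called first, only, known or untested is meant among the compounds shown, and "the series" means these compounds.

Three related compounds have been tested in an ADME assay on HEp-2 cells (Homo sapiens) for cytotoxicity, read by MTT assay, with a stated time of 3 days; a higher number here means that more compound is tolerated, a lower number that less compound is tolerated. There compound 2 (`CCC[C@@H](CCn1cncn1)c1ccc(Cl)cc1`) gives 36.6 ug/mL. That number lies within the usual scatter of compound 3 (`CCC[C@H](CCn1cncn1)c1ccc(C)cc1`) at 45.7 ug/mL. Compound 1 (`CC[C@H](CCn1cncn1)c1ccc(C)cc1`) stands at 75.2 ug/mL, and the number of compound 2 lies beyond the scatter from it, on the lower side. Compound 4 (`CCC[C@@H](CCn1cncn1)c1ccc(C)cc1`) has not yet been measured. Its structure departs from that of compound 2 by a single exchange, (methyl in place of chloro on an aromatic carbon), which is methyl in place of chloro on an aromatic carbon.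

For the measured compounds named here, no measured step covers this exchange directly. Going by the values given here, the one step available, a 1.6-fold lower number from compound 1 to compound 3 (0.22 log units; within the scatter), lies within the scatter, and it concerns a methyl on a saturated chain carbon rather than on the aromatic carbon. Compound 4 carries the same methyl on the aromatic carbon as compound 3, the closest guide, which stands at 45.7 ug/mL, within the scatter of compound 2. Compound 1 also carries that methyl, yet its number lies further off, so the guide is a loose one. No step beyond the scatter is therefore expected in this assay, and no direction can be favoured. The expected size is a 1.2-fold higher number from compound 2 to compound 4 (0.08 log units; within the scatter). The estimate for compound 4 is 44 ug/mL, with an expected range of 25 ug/mL to 75 ug/mL.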

Compound 4, half-maximal cytotoxic concentration: 71.3 ug/mL
Compound 4: middle estimate off by 1.6-fold (0.21 log units), on the low side; measured number inside the range.
By their numbers in this assay, from the lowest: compounds 2, 3, 4 and 1 (each within the scatter of the next, the first and the last beyond it).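

The exchange of chloro for methyl on an aromatic carbon, para to a large group, now has a direct reading in this assay: a 1.9-fold higher number from compound 2 to compound 4 (0.29 log units; within the scatter), so this change at this position does not carry the compounds beyond the usual scatter, although the step sits close to its edge. The earlier compounds shown here offered only a methyl on a saturated chain carbon and gave no reading of a change in configuration, which the second new step now supplies: a 1.6-fold higher number from compound 3 to compound 4 (0.19 log units; within the scatter), again within the scatter, so the two drawn configurations at this stereocentre cannot be told apart in this assay with the propyl-bearing, methyl-substituted compounds. That second step can be laid on the stereocentre alone, and the ground for doing so is: the fact that compounds 3 and 4 differ only in the configuration as drawn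

The compounds shown leave open how an amine or a carboxylic acid on the same aromatic carbon would read, and whether a longer chain at the stereocentre would stay within the scatter. They also leave open whether configuration matters alongside chloro or alongside the shorter chain, as each of these appears in one configuration only.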